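The compounds below may be only part of what the source reports. "The series", "measured", "known", "first", "only" and "open" are said of these compounds alone.

Series around the shared core of compound 1 `OC[C@H](NC1CCN(CCCc2c[nH]c3ccc(-n4ccnc4)cc23)CC1)c1ccccc1`. Among the measured compounds shown here, compound 1 gives 0.8 nM in an assay on CHO cells for agonist activity at 5-hydroxytryptamine receptor 1D (Homo sapiens), read by GTPgammaS binding (on this read-out higher numbers stand for an effect only at larger amounts of compound and lower numbers for an effect already at smaller amounts), the lower of the two numbers measured so far. For the measured compounds named here, the one measured step in this assay concerns the amine side of the core: compound 2 `C[C@@H](NC1CCN(CCCc2c[nH]c3ccc(-n4ccnc4)cc23)CC1)c1ccccc1` gives 6.2 nM, a step of a 7.8-fold higher number from compound 1 to compound 2 (0.89 log units; beyond the scatter). Compound 3 `OC[C@H](NC1CCN(CCCc2c[nH]c3ccc(-n4cncn4)cc23)CC1)c1ccccc1` differs from compound 1 elsewhere, by 1H-1,2,4-triazol-1-yl in place of 1H-imidazol-1-yl on an aromatic carbon. Going by the values given here, no measured step in this assay touches that ring, so the step from compound 1 to compound 2 does not bear on it and gives no direction for it. With nothing in the measured pairs to argue otherwise, a step within the scatter is expected, with the wider side of the range allowed toward higher numbers. Compound 3 is therefore estimated at 1.3 nM, a range of 0.4 nM to 5 nM, meaning an expected step of a 1.6-fold higher number from compound 1 to compound 3 (0.21 log units; within the scatter).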

Compound 3, half-maximal effective concentration: 7.4 nM
The estimate for compound 3 lay 5.7-fold (0.76 log units) below the measured number; the measured number lies above the stated range.
By their numbers in this assay, from the lowest: compound 1; then compounds 2 and 3 (each within the scatter of the next).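

In this assay, the aromatic carbon carrying the 1H-imidazol-1-yl group of compound 1 proves sensitive to the ring placed on it: 1H-1,2,4-triazol-1-yl in its place brings a 9.3-fold higher number from compound 1 to compound 3 (0.97 log units; beyond the scatter) on this read-out. Both groups are five-membered aromatic rings with the same count of heavy atoms and no net charge, and the entering ring holds a nitrogen in place of a carbon, so even this small exchange moves the number beyond the scatter. Nothing available explains the rise.

Still open, on these data alone, is whether the step would keep its size with the 1-phenylethyl amine side of compound 2. Also open, as far as these compounds go, is how a tetrazol-1-yl, a pyridin-3-yl or a plain carboxamide on this aromatic carbon would read in this assay against the two rings seen so far.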